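A Smaller Amine Ring on the Carbonyl

The source may report more compounds than this note shows. Statements on the series, on what has been measured and on what is new or still open speak of the compounds shown alone.

In an in vitro ADME assay on microsomes from liver (Rattus norvegicus) for metabolic stability, tested at 1 uM (a higher number here means that the compound lasts longer, a lower number that the compound disappears faster), compound 1 `O=C(c1ccc(Cl)nc1)N1CCC(NS(=O)(=O)c2cc(S(=O)(=O)c3ccccc3)ccc2C(F)(F)F)CC1` gives 0.15 h. Compound 2 `O=C(CC1CCNCC1)N1CCC(NS(=O)(=O)c2cc(S(=O)(=O)c3ccccc3)ccc2C(F)(F)F)CC1` gives > 0.5 h, a limit of the assay and not a number. That puts compound 2 at the limit of > 0.5 h in this assay, at which 1 of the 2 values shown sits.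

Compound 3 `O=C([C@H]1CCNC1)N1CCC(NS(=O)(=O)c2cc(S(=O)(=O)c3ccccc3)ccc2C(F)(F)F)CC1` keeps the shared core and changes one group: pyrrolidin-3-yl in place of (piperidin-4-yl)methyl on a carbonyl carbon. In words, this is pyrrolidin-3-yl in place of (piperidin-4-yl)methyl on a carbonyl carbon. Among the measured compounds shown here, only one measured step bears on this change: an at least 3.3-fold higher number from compound 1 to compound 2 (0.52 log units; beyond the scatter), in which (piperidin-4-yl)methyl took the place of 6-chloropyridin-3-yl. That step started from a different group, so it offers only a loose guide and gives no direction here. One non-aromatic ring with a hetero atom simply follows another, so no shift beyond the scatter is expected, and the estimated change is a step that the limit leaves unreadable from compound 2 to compound 3. For compound 3 the expected half-life is 0.6 h, with an estimated range of 0.25 h to 1.3 h.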

Compound 3, half-life: > 0.5 h
Compound 3 ended at the assay's limit; the forecaster's own chance of this, stated with the estimate: 60%; the middle value is on the limit's open side.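

Pyrrolidin-3-yl on the carbonyl carbon, in place of 6-chloropyridin-3-yl, gives an at least 3.3-fold higher number from compound 1 to compound 3 (0.52 log units; beyond the scatter) in this assay, so the rise seen with compound 2 does not rest on the (piperidin-4-yl)methyl group alone. Among these three compounds, compound 2 and compound 3 carry a non-aromatic ring with 1 hetero atom on this carbonyl and reach the limit, while compound 1, with its 6-chloropyridin-3-yl, does not. How compound 2 and compound 3 compare cannot be read, because both values are limits and not numbers: the limit of > 0.5 h in this assay, at which 2 of the 3 values shown sit.

On these data alone, how much longer either compound lasts beyond that limit stays open. Also open, as far as these compounds go, is whether a ring matters here at all, which a simple open-chain amine such as 2-aminoethyl on the same carbonyl would test.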